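The source may report more compounds than this note shows. Statements on the series, on what has been measured and on what is new or still open speak of the compounds shown alone.

Measured so far in an assay on isolated protein (Cavia porcellus) with Sigma non-opioid intracellular receptor 1 (Homo sapiens) as the target, read by radioligand binding; a lower number here means a stronger inhibitor, a higher number a weaker inhibitor:
compound 1 `O=c1cc(-c2ccccc2)oc2ccc(OCCCCCCN3CCC(O)CC3)cc12`, 100 nM
compound 2 `O=c1cc(-c2ccccc2Cl)oc2ccc(OCCCCCCN3CCC(O)CC3)cc12`, 47 nM

Compound 2 stands lowest of the two numbers in this assay; compound 1 sits above it. Compound 3 `O=c1cc(-c2cccs2)oc2ccc(OCCCCCCN3CCC(O)CC3)cc12` differs from compound 2 by thiophen-2-yl in place of 2-chlorophenyl on an aromatic carbon. For the measured compounds named here, one measured step bears on this: a 2.1-fold lower number from compound 1 to compound 2 (0.33 log units; beyond the scatter), a modest gain from the chloro. Going by the values given here, that chloro leaves together with the phenyl here, and no measured pair tells what thiophen-2-yl itself brings. The number for compound 3 is therefore expected to rise somewhat, a 1.8-fold higher number from compound 2 to compound 3 (0.26 log units; within the scatter). Compound 3 is estimated at 85 nM, with a range from 35 nM to 210 nM.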

Compound 3, half-maximal inhibitory concentration: 119 nM
Compound 3: middle estimate off by 1.4-fold (0.15 log units), on the low side; the measured number falls inside the stated range.
By their numbers in this assay, from the lowest: compound 2; then compounds 1 and 3 (each within the scatter of the next).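

In this assay, at the aromatic carbon next to the ring oxygen, thiophen-2-yl in place of 2-chlorophenyl gives a 2.5-fold higher number from compound 2 to compound 3 (0.40 log units; beyond the scatter), so the lower number of compound 2 is not kept. Thiophen-2-yl in place of phenyl gives a 1.2-fold higher number from compound 1 to compound 3 (0.08 log units; within the scatter), so the five-membered ring with sulfur and the plain phenyl cannot be told apart here. No measurement available explains either step.

From the compounds shown here alone, whether a chloro on the thiophen-2-yl would bring the number down remains open. So does how furan-2-yl, pyridin-2-yl or 4-chlorophenyl would compare at this position.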